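A few compounds are considered here, and "the series" means these few. Any claim that something is new, unique, unknown or untested is made for them only; others in the source may bear on it.

Within the data shown here, in an ADME assay on MDCK cells (Canis lupus familiaris) for cytotoxicity, read by MTT assay, with a stated time of 72 h (a lower number here means that less compound is tolerated, a higher number that more compound is tolerated), only two compounds have a measured number so far. Compound 1 `Cc1nc([N+](=O)[O-])cn1S(=O)(=O)c1ccccc1` gives 1270000 nM, and compound 2 `Cc1ccc(S(=O)(=O)n2cc([N+](=O)[O-])nc2C)cc1` gives 988000 nM. Among the measured compounds shown here, these two values lie within the scatter of each other, so compound 2 stands level with the only other compound measured. Compound 3 `Cc1nc([N+](=O)[O-])cn1S(=O)(=O)c1ccc(F)cc1` keeps the shared core and departs from compound 2 at one place: fluoro in place of methyl on an aromatic carbon. This is fluoro in place of methyl on an aromatic carbon, para to a large group.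

For the measured compounds named here, one measured step bears on this carbon, a 1.3-fold lower number from compound 1 to compound 2 (0.11 log units; within the scatter). It swaps hydrogen for methyl and leaves the two values indistinguishable in this assay. Going by the values given here, no measured compound carries fluoro, so the data give no direct reading of that group. Among the compounds with values here, the one step available offers no reason to expect a shift beyond the scatter, in either direction. The value expected for compound 3 is 1100000 nM, with an estimated range of 600000 nM to 2000000 nM. The estimated change is a 1.1-fold higher number from compound 2 to compound 3 (0.05 log units; within the scatter), and it is expected to stay within the scatter.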

Compound 3, half-maximal cytotoxic concentration: 813000 nM
Compound 3: middle estimate off by 1.4-fold (0.13 log units), on the high side, and the stated range covers the measured number.
By their numbers in this assay, from the lowest: compounds 3, 2 and 1 (each within the scatter of the next).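

In this assay this carbon now has a fluoro reading, and both steps that end in fluoro stay within the scatter, whether it replaces methyl (a 1.2-fold lower number from compound 2 to compound 3 (0.08 log units; within the scatter)) or hydrogen (a 1.6-fold lower number from compound 1 to compound 3 (0.19 log units; within the scatter)). Hydrogen, methyl and fluoro on this aromatic carbon, para to a large group, therefore give numbers that this assay does not separate, and the step between the two most distant of the three compounds is still within the scatter. Nothing in the available data explains this lack of separation.

Only three single small substituents are shown at this one place, so it remains open whether an amine, a carboxylic acid, a methoxy group or a longer chain on the same carbon would move the number beyond the scatter. Compound 1, compound 2 and compound 3 also share the rest of their structure, which leaves open whether a change elsewhere on the shared core would shift the tolerated concentration more than any change at this carbon has so far.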